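The compounds below may be only part of what the source reports. "The series", "measured", "known", "first", "only" and "open" are said of these compounds alone.

Measured so far:

Compound 1, `CCCCc1ccc(-c2c(C)[nH]c(=O)n2C)cc1`, gives 10700 nM in a functional assay on brain (Rattus norvegicus, strain Wistar) for inhibition; on this read-out lower numbers stand for stronger inhibition and higher numbers for weaker inhibition.
Compound 2, `CCCCCCc1ccc(-c2c(C)[nH]c(=O)n2C)cc1`, gives 9000 nM in this assay.
Compound 3, `CCCCCCCCOc1ccc(-c2c(C)[nH]c(=O)n2C)cc1`, gives 4000 nM in this assay.

The three share a core carrying a chain on the aromatic ring. Compound 1 and compound 2 differ by one change, (ethyl in place of hydrogen on a saturated chain carbon, four bonds along the chain from an aromatic carbon), and the step that this change made is a 1.2-fold lower number from compound 1 to compound 2 (0.08 log units; within the scatter). Compound 3 carries its chain through an oxygen; the difference between its core and that of compound 1 is not broken down here, and the values only show that compound 3 sits beyond the scatter from both compound 1 and compound 2.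

Compound 4, `CCCCCCCCCCOc1ccc(-c2c(C)[nH]c(=O)n2C)cc1`, has not yet been measured. It differs from compound 3 by ethyl in place of hydrogen on a saturated chain carbon, eight bonds along the chain from an oxygen on an aromatic ring. Among the compounds with values here, this is the same kind of change as the one from compound 1 to compound 2, but the place is not the same: there the chain carbon sits four bonds along the chain from an aromatic carbon, here eight bonds along the chain from an oxygen on an aromatic ring.

Since the earlier step of this kind was a 1.2-fold lower number from compound 1 to compound 2 (0.08 log units; within the scatter) and stayed within the scatter, the step from compound 3 to compound 4 is expected to be modest, about a 1.3-fold lower number from compound 3 to compound 4 (0.10 log units; within the scatter), with the change of place adding uncertainty. Compound 4 is therefore expected to give about 3200 nM in this assay, most likely between 1300 nM and 8000 nM.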

Compound 4, half-maximal inhibitory concentration: 6900 nM
Estimate against measurement, compound 4: 2.2-fold (0.33 log units) below; the range from low to high includes it.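

In this assay the new step is a 1.7-fold higher number from compound 3 to compound 4 (0.24 log units; within the scatter), so on this read-out compound 3 and compound 4 cannot be told apart. Set beside the earlier step, ethyl in place of hydrogen does not read differently on the two cores: the same change on two cores in this assay, a 1.2-fold lower number (0.08 log units; within the scatter) from compound 1 to compound 2 and a 1.7-fold higher number (0.24 log units; within the scatter) from compound 3 to compound 4, 2.1-fold (0.31 log units) apart, within the scatter of two such steps

This shows that, in the two pairs available, the change stayed within the scatter on both the core of compound 1 and the core of compound 3, which is consistent with a small step carrying over from one to the other. Within the data shown here, it does not show that the step is the same on both cores, only that the measurements do not separate the two steps, and it cannot divide any contribution of the core from that of the place, as the chain carbon sits four bonds along the chain from an aromatic carbon in one pair and eight bonds along the chain from an oxygen on an aromatic ring in the other.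

The compounds shown leave open whether a longer chain than that of compound 4 would give a step beyond the scatter. They also leave open how an amine or a carboxylic acid in place of the ethyl would read in this assay.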